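Swapping 1,3-thiazol-2-yl for 1,3-oxazol-2-yl on compound 2

The source may report more compounds than this note shows. Statements on the series, on what has been measured and on what is new or still open speak of the compounds shown alone.

Going by the values given here, in a functional assay on MCF7 cells (Homo sapiens) for inhibition, with a stated time of 96 h (on this read-out higher numbers stand for weaker inhibition and lower numbers for stronger inhibition), compound 2 (`COc1cc(C(=O)c2cn(-c3ccc(F)cc3)cc2-c2nccs2)cc(OC)c1OC`) gives 22 nM as the lower of the two numbers so far, while compound 1 (`COc1cc(C(=O)c2cn(-c3cccc(C)c3)cc2-c2ncco2)cc(OC)c1OC`) gives 75 nM at a distance beyond the scatter. Compound 3 (`COc1cc(C(=O)c2cn(-c3ccc(F)cc3)cc2-c2ncco2)cc(OC)c1OC`) has 1,3-oxazol-2-yl in place of 1,3-thiazol-2-yl on an aromatic carbon. Compound 1 holds the same 1,3-oxazol-2-yl at 75 nM but differs elsewhere too, so it suggests only a direction. A small rise within the scatter is expected, estimated as a 1.8-fold higher number from compound 2 to compound 3 (0.26 log units; within the scatter) in this assay for this change. For compound 3 the expected value is 40 nM (estimated range 15 nM to 110 nM).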

Compound 3, half-maximal inhibitory concentration: 93 nM
Beside the measured number, compound 3's estimate is 2.3-fold (0.37 log units) below it; low and high end bracket the measured number.
By their numbers in this assay, from the lowest: compound 2; then compounds 1 and 3 (each within the scatter of the next).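

In this assay, going by these compounds alone, with 4-fluorophenyl held fixed, 1,3-oxazol-2-yl in place of 1,3-thiazol-2-yl gives a 4.2-fold higher number from compound 2 to compound 3 (0.63 log units; beyond the scatter), the first single-change reading at this position, and it favours 1,3-thiazol-2-yl. With 1,3-oxazol-2-yl held fixed, 4-fluorophenyl in place of 3-methylphenyl on the aromatic nitrogen gives a 1.2-fold higher number from compound 1 to compound 3 (0.09 log units; within the scatter), so that change does not separate the two compounds. Still open, from the compounds shown here alone, is whether the preference for 1,3-thiazol-2-yl holds with 3-methylphenyl on the nitrogen, and whether an amine or a nitrile at this position retains inhibition. No supporting data bear on the origin of the step from 1,3-thiazol-2-yl to 1,3-oxazol-2-yl.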